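Methyl Additions on the Imidazole of Two Related Cores

The source may hold more compounds than are shown below. What is called first, only, known or untested is meant among the compounds shown, and "the series" means these compounds.

Compound 1, `COc1ccc(Br)cc1CCc1c(Cl)cccc1-c1nccn1C(C)C`, gives 670 nM in an assay on isolated protein for binding affinity to Melanocortin receptor 4 (Homo sapiens); a lower number here means a stronger inhibitor, a higher number a weaker inhibitor.
Compound 2, `CCC(C)n1ccnc1-c1cccc(Cl)c1CCc1cc(Br)ccc1OC`, gives 2500 nM in this assay.
Compound 3, `COc1ccc(Br)cc1CCc1ccccc1-c1ncc(C)n1C`, gives 180 nM in this assay.

Compound 1 and compound 2 share a core and differ in one place: methyl in place of hydrogen on a saturated chain carbon, two bonds along the chain from an aromatic nitrogen. That change carries a step of a 3.7-fold higher number from compound 1 to compound 2 (0.57 log units; beyond the scatter), a modest loss that lies beyond the scatter. Compound 3 is built on a different core; the difference between the two cores is not broken down here. Of the three numbers, compound 3 stands lowest, and its steps to compound 1 and to compound 2 both lie beyond the scatter.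

Compound 4, `CCc1cnc(-c2ccccc2CCc2cc(Br)ccc2OC)n1C`, has not yet been measured in this assay. It differs from compound 3 by methyl in place of hydrogen on a saturated chain carbon bound to an aromatic carbon. Going by the values given here, this is the same kind of change as the one from compound 1 to compound 2, a methyl in place of hydrogen on a saturated chain carbon, but the surroundings of the place are not the same: in the earlier pair the carbon sits two bonds along the chain from an aromatic nitrogen, whereas in compound 4 it is bound to an aromatic carbon. Among the compounds with values here, only one instance of this kind of change has been measured, and it was on another core, so the expectation rests on a single step.

Compound 4 is therefore expected to show a step of a 2.5-fold higher number from compound 3 to compound 4 (0.40 log units; beyond the scatter) from compound 3, a loss somewhat smaller than the step from compound 1 to compound 2 because that step, a 3.7-fold higher number from compound 1 to compound 2 (0.57 log units; beyond the scatter), was made at a differently placed carbon. The estimate for compound 4 in this assay is 450 nM, with a range from 150 nM to 1400 nM.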

Compound 4, inhibition constant: 320 nM
For compound 4 the middle estimate is 1.4-fold (0.15 log units) above the measured one; measured number inside the range.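

On the core of compound 3, methyl in place of hydrogen on a saturated chain carbon bound to an aromatic carbon gives a 1.8-fold higher number from compound 3 to compound 4 (0.25 log units; within the scatter) in this assay, so this read-out does not separate the 5-ethyl-1-methyl-1H-imidazol-2-yl group from the 1,5-dimethyl-1H-imidazol-2-yl group. Set beside the earlier step on the other core, the new step does not differ from it by more than two such steps can be expected to scatter: the same change on two cores in this assay, a 3.7-fold higher number (0.57 log units; beyond the scatter) from compound 1 to compound 2 and a 1.8-fold higher number (0.25 log units; within the scatter) from compound 3 to compound 4, 2.1-fold (0.32 log units) apart, within the scatter of two such steps This agreement is compatible with the change carrying over from one core to the other, but it does not establish a shared size for the step, since only two pairs are available, one step lies beyond the scatter and the other within it, and the carbon that changes is placed differently in each pair.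

The compounds shown leave open whether the same change made at a carbon bound to an aromatic carbon would read alike on the core of compound 1. They also leave open how a longer chain such as propyl, or a chain ending in an amine or a carboxylic acid, would fare in place of the ethyl group of compound 4.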